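Moving a fluoro across two related purine-linked cores

The source may hold more compounds than are shown below. What is called first, only, known or untested is meant among the compounds shown, and "the series" means these compounds.

Measured so far:
- compound 1, `c1ccc(Sc2ncnc3c2ncn3C2COc3ccccc3CO2)cc1`: 7120 nM
- compound 2, `Fc1ccc(Sc2ncnc3c2ncn3C2COc3ccccc3CO2)cc1`: 11200 nM
- compound 3, `c1ccc(Sc2ncnc3ncn(C4COc5ccccc5CO4)c23)cc1`: 15600 nM

All three numbers come from a functional assay on MCF7 cells (Homo sapiens) for antiproliferative activity, read by sulforhodamine B assay, with a stated time of 3 days; a higher number here means a weaker inhibitor, a lower number a stronger inhibitor. Compound 1 gives 7120 nM in this assay, and compound 2, which carries the change (fluoro in place of hydrogen on an aromatic carbon), gives 11200 nM. The step of a 1.6-fold higher number from compound 1 to compound 2 (0.20 log units; within the scatter) is small enough to fall within the ordinary variation of repeated measurements, so the fluoro did not clearly alter the result here.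

Compound 3 has the same atoms as compound 1 joined differently; the difference between the two cores is not broken down here. In this assay compound 3 gives 15600 nM, a number beyond the scatter from that of compound 1, while compound 2 and compound 3 sit within the scatter of each other.

Compound 4, `Fc1ccc(Sc2ncnc3ncn(C4COc5ccccc5CO4)c23)cc1`, has not been measured. It differs from compound 3 by fluoro in place of hydrogen on an aromatic carbon, and the place of this change is described in exactly the same words as for the step from compound 1 to compound 2, so it is the same change, now made on the other core. Because a 1.6-fold higher number from compound 1 to compound 2 (0.20 log units; within the scatter) was within the scatter, the expected step of a 1.5-fold higher number from compound 3 to compound 4 (0.19 log units; within the scatter) is of similar modest size. Compound 4 is therefore estimated at 24000 nM, with a plausible range from 12000 nM to 48000 nM.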

Compound 4, half-maximal inhibitory concentration: 14100 nM
For compound 4 the middle estimate is 1.7-fold (0.23 log units) above the measured one; the measured number falls inside the stated range.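

On the second core the same swap of hydrogen for fluoro, turning phenylsulfanyl into (4-fluorophenyl)sulfanyl, gives in this assay a 1.1-fold lower number from compound 3 to compound 4 (0.04 log units; within the scatter), so the change makes no clear difference to the result on this core either. Set beside the earlier step, the result on the second core is no different from that on the first, as the gap between the two steps is no larger than ordinary variation allows: the same change on two cores in this assay, a 1.6-fold higher number (0.20 log units; within the scatter) from compound 1 to compound 2 and a 1.1-fold lower number (0.04 log units; within the scatter) from compound 3 to compound 4, 1.7-fold (0.24 log units) apart, within the scatter of two such steps

This shows that, for these two pairs, the change carried from one core to the other without a clear effect on either, but it does not show that fluoro is truly without effect, and the printed steps point in opposite directions only within the scatter, so no shared direction can be read from them, and two pairs cannot support a rule for other cores or other cell lines.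

The compounds shown leave open whether a different group on the same phenyl ring, such as a methoxy, an amine or a carboxylic acid, would move the number beyond the scatter. They also leave open what a longer chain in place of phenylsulfanyl would do on either core.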